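A few compounds are considered here, and "the series" means these few. Any claim that something is new, unique, unknown or untested is made for them only; others in the source may bear on it.

Working notes on the series sharing the core of compound 1 `CC(=O)Nc1ccc(NC(=O)c2cc(Cl)ccc2O)c(Cl)c1`, which in an ADME assay on A549 cells (Homo sapiens) for cytotoxicity, read by resazurin assay, with a stated time of 48 h (a lower number here means that less compound is tolerated, a higher number that more compound is tolerated), has "not determined" (no result reported). Going by the values given here, compound 2 `CN(C)c1ccc(NC(=O)c2cc(Cl)ccc2O)c(Cl)c1` in this assay gives 85100 nM, and compound 3 `O=C(Nc1ccc(NCc2ccc(F)cc2)cc1Cl)c1cc(Cl)ccc1O` gives 54400 nM; the two numbers sit within the scatter of each other, so neither is told apart from the other, and these are the only two numbers in hand.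

Compound 4 `CC(C)(CCO)Nc1ccc(NC(=O)c2cc(Cl)ccc2O)c(Cl)c1` is the next entry, not yet measured. Against compound 3 the change is 3-hydroxy-1,1-dimethylpropyl in place of 4-fluorobenzyl on a nitrogen on an aromatic ring. Among the compounds with values here, the one measured step that bears on this position is the swap on the same nitrogen, a 1.6-fold lower number from compound 2 to compound 3 (0.19 log units; within the scatter), which stayed within the scatter. Two groups of quite different kind have thus been exchanged at this nitrogen without a step beyond the scatter, and a third exchange there is read the same way. The expectation for this assay is therefore no step beyond the scatter, in no particular direction: the estimated step is a 1.1-fold higher number from compound 3 to compound 4 (0.04 log units; within the scatter). Within the data shown here, compound 4 is accordingly estimated at 60000 nM, with a range from 25000 nM to 150000 nM, the width reflecting that only one prior step at this position exists.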

Compound 4, half-maximal cytotoxic concentration: 170000 nM
The estimate for compound 4 lay 2.8-fold (0.45 log units) below the measured number; measured number above the stated range.
By their numbers in this assay, from the lowest: compounds 3, 2 and 4 (each within the scatter of the next, the first and the last beyond it).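

In this assay the nitrogen on an aromatic ring can carry a change that moves the number beyond the scatter: 3-hydroxy-1,1-dimethylpropyl in place of 4-fluorobenzyl gives a 3.1-fold higher number from compound 3 to compound 4 (0.49 log units; beyond the scatter), whereas the earlier exchange at this nitrogen, a 1.6-fold lower number from compound 2 to compound 3 (0.19 log units; within the scatter), did not leave the scatter. The separation is limited to this one pair, since a 2.0-fold higher number from compound 2 to compound 4 (0.30 log units; within the scatter) stays within the scatter, so compound 4 is told apart from compound 3 but not from compound 2 and the position shows only a modest range so far. No supporting measurement is available to account for the step.

The change removes the six-membered aromatic ring and the fluorine and brings in the hydroxyl and the branched chain all at once, and the compounds shown do not separate these contributions. A plain 3-hydroxypropyl group, a 1,1-dimethylpropyl group without the hydroxyl or an unsubstituted benzyl group on this nitrogen would each bear on which part of the change goes with the step.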